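Swapping a Methyl for a Fluoro on the Phenyl Ring

The compounds below may be only part of what the source reports. "The series", "measured", "known", "first", "only" and "open" are said of these compounds alone.

Compound 1 `Cc1cccc(NC(=O)CN2CCC(c3nccs3)CC2)c1` and compound 2 `Cc1cccc(NC(=O)CN2CCC(c3ccccc3C)CC2)c1` share one core and differ only at a saturated ring carbon. In a functional assay on HEK293 cells for agonist activity at D(4) dopamine receptor (Homo sapiens), read by FLIPR (on this read-out higher numbers stand for larger maximal responses and lower numbers for smaller maximal responses), compound 1 gives 62%, and compound 2 gives 43%, the lower of the two numbers; the change is a number 19 percentage points lower from compound 1 to compound 2 (beyond the scatter). Compound 3 `Cc1cccc(NC(=O)CN2CCC(c3ccccc3F)CC2)c1` carries fluoro in place of methyl on an aromatic carbon. For the measured compounds named here, no measured step touches that aromatic ring, so the step between compound 1 and compound 2 gives no guide to direction or size here. A change within the scatter is therefore expected for compound 3, namely a number 2 percentage points higher from compound 2 to compound 3 (within the scatter). Compound 3 is estimated at 45%, between 30% and 62%.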

Compound 3, largest response reached (reported as efficacy), in percent of the reference or control that the assay uses: 57%
The estimate for compound 3 lay 12 percentage points below the measured number; the range from low to high includes it.
By their numbers in this assay, from the lowest: compound 2; then compounds 3 and 1 (each within the scatter of the next).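

This carbon on the aromatic ring responds to a single-atom exchange: in this assay, fluoro in place of methyl gives a number 14 percentage points higher from compound 2 to compound 3 (beyond the scatter), so the response is not fixed by the ring alone. With the 2-fluorophenyl group, the result is a number 5 percentage points lower from compound 1 to compound 3 (within the scatter), which leaves it and the 1,3-thiazol-2-yl group indistinguishable on this read-out. Nothing available explains why the exchange raises the response. Still open, from the compounds shown here alone, is what a chloro or methoxy group on this carbon would give, and whether fluoro elsewhere on the ring would do the same.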